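The source may hold more compounds than are shown below. What is called first, only, known or untested is meant among the compounds shown, and "the series" means these compounds.

Compound 1 `COc1ccc(CN(c2cc(OC)c(OC)c(OC)c2)S(=O)(=O)c2ccc(C)cc2)cc1` — 8220 nM in a functional assay on PC-3 cells (Homo sapiens) for inhibition, read by MTT assay, with a stated time of 48 h; on this read-out higher numbers stand for weaker inhibition and lower numbers for stronger inhibition
Compound 2 `COc1cc(N(Cc2cccc(C)c2)S(=O)(=O)c2ccc(C)cc2)cc(OC)c1OC` — 8580 nM in this assay

Compound 2 stands at the higher of the two numbers, yet a 1.0-fold higher number from compound 1 to compound 2 (0.02 log units; within the scatter) is within the scatter. Compound 3 `COc1cc(N(Cc2ccccc2)S(=O)(=O)c2ccc(C)cc2)cc(OC)c1OC` differs from compound 2 by hydrogen in place of methyl on an aromatic carbon. Within the data shown here, the only measured step bearing on this is a 1.0-fold higher number from compound 1 to compound 2 (0.02 log units; within the scatter), where one substituted benzyl replaced another on the saturated chain carbon bound to the sulfonamide nitrogen without moving the number. Removing the remaining methyl from that ring is therefore expected to give no step beyond the scatter, a 1.0-fold lower number from compound 2 to compound 3 (0.00 log units; within the scatter). Compound 3 is estimated at 8500 nM, between 4000 nM and 18000 nM.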

Compound 3, half-maximal inhibitory concentration: 7810 nM
For compound 3 the middle estimate is 1.1-fold (0.04 log units) above the measured one, within the range that was stated.
By their numbers in this assay, from the lowest: compounds 3, 1 and 2 (each within the scatter of the next).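

In this assay a phenyl ring carrying no substituent at all reads the same as the methyl-bearing ring (a 1.1-fold lower number from compound 2 to compound 3 (0.04 log units; within the scatter)) and the methoxy-bearing ring (a 1.1-fold lower number from compound 1 to compound 3 (0.02 log units; within the scatter)). Among these compounds, the earlier pair compared only two substituted rings, whereas these steps show that neither substituent is needed to hold the number at this level. Nothing available accounts for this flatness.

The compounds shown leave open whether an amine or a carboxylic acid on this ring would move the number beyond the scatter. They also leave open whether a longer chain to the sulfonamide nitrogen would do so.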